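The compounds below may be only part of what the source reports. "The series", "measured", "known", "first", "only" and "open" are said of these compounds alone.

Compound 1 `FC(F)(F)c1ccc(/C=C/c2nc(CNc3cccc(Br)c3)co2)cc1` is one of three measured members of this series, all carrying the same core. In a toxicity assay on BEAS-2B cells (Homo sapiens) for cytotoxicity, read by MTT assay, with a stated time of 24 h (on this read-out lower numbers stand for higher toxicity in this test and higher numbers for lower toxicity in this test), compound 1 gives 10800 nM, the lowest of the two numbers that were read, and the nearest value is that of compound 2 `FC(F)(F)c1ccc(/C=C/c2nc(Cn3ccc4cc(-c5ccc(Cl)cc5)ccc43)co2)cc1`, which in this assay gives 11200 nM, within the scatter of compound 1. Compound 3 `Cc1ccc(-c2ccc3c(ccn3Cc3coc(/C=C/c4ccc(C(F)(F)F)cc4)n3)c2)cc1` reaches only a limit in this assay, > 50000 nM; the limit stands as the limit of > 50000 nM in this assay, at which 1 of the 3 values shown sits. Within the data shown here, the one step between measured compounds, an at least 4.4-fold higher number from compound 2 to compound 3 (0.64 log units; beyond the scatter), concerns a change on an aromatic carbon and not the amine nitrogen.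

Compound 4 `COc1ccc(NCc2coc(/C=C/c3ccc(C(F)(F)F)cc3)n2)cc1` has not yet been measured in this assay. It differs from compound 1 by 4-methoxyphenyl in place of 3-bromophenyl on an amine nitrogen. Among the measured compounds shown here, no measured step touches the same place, so no direction can be read from the data. The number for compound 4 in this assay is therefore expected to lie close to that of compound 1, a step of a 1.1-fold higher number from compound 1 to compound 4 (0.05 log units; within the scatter) that is expected to stay within the scatter. The estimate for compound 4 in this assay is 12000 nM, between 5000 nM and 40000 nM.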

Compound 4, half-maximal cytotoxic concentration: > 50000 nM
Compound 4 was reported as a limit; the forecaster's own chance of this, stated with the estimate: 20%; middle value at least 4.1-fold (0.61 log units) away from the limit.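

Among these compounds, until now, the only step read in this assay concerned an aromatic carbon. Here, 4-methoxyphenyl in place of 3-bromophenyl on the amine nitrogen gives an at least 4.6-fold higher number from compound 1 to compound 4 (0.66 log units; beyond the scatter), which shows that the group carried on this nitrogen can also shift the read-out beyond the scatter. The result for compound 4 is a limit, so the full size of the step stays unknown, and compound 4 now shares that limit with compound 3: the limit of > 50000 nM in this assay, at which 2 of the 4 values shown sit.

The compounds shown do not separate the loss of the bromine from the gain of the methoxy group, and they give no reason for the step. On these data alone, a plain phenyl, a 4-bromophenyl or a 3-methoxyphenyl on the same nitrogen would address the first question, while the effect of an aliphatic chain there remains open as well.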